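A few compounds are considered here, and "the series" means these few. Any claim that something is new, unique, unknown or untested is made for them only; others in the source may bear on it.

Measured so far:
Compound 1, `C=C1[C@@H](O)C[C@H]2C(C)(C)CCC[C@]2(C)[C@H]1/C=C/C1=CC(=O)OC1O`: 7.29 ug/mL
Compound 2, `C=C1[C@@H](O)C[C@H]2C(C)(C)CCC[C@]2(C)[C@H]1/C=C/C1=CCOC1=O`: 14.5 ug/mL

In a functional assay on SGC-7901 cells (Homo sapiens) for cytotoxicity, read by sulforhodamine B assay, with a stated time of 48 h (a lower number here means a stronger inhibitor, a higher number a weaker inhibitor), compound 1 gives 7.29 ug/mL, and compound 2 gives 14.5 ug/mL. Among the measured compounds shown here, compound 2 stands beside compound 1, and the only measured step, a 2.0-fold higher number from compound 1 to compound 2 (0.30 log units; within the scatter), concerns the group on the double-bonded chain carbon, not the saturated ring. Compound 3, `C=C1[C@@H](O)[C@@H](O)[C@H]2C(C)(C)CCC[C@]2(C)[C@H]1/C=C/C1=CCOC1=O`, differs from compound 2 by hydroxy in place of hydrogen on a saturated ring carbon. For the measured compounds named here, no measured step bears on this change, so the expectation is a step of no change at the digits printed from compound 2 to compound 3 (within the scatter), that is, nothing beyond the scatter. Compound 3 is therefore estimated at 14.5 ug/mL, within 7 ug/mL to 30 ug/mL.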

Compound 3, half-maximal inhibitory concentration: > 25 ug/mL
Compound 3 gave a limit, no number (the forecaster's own chance of this, stated with the estimate: 5%); at least 1.7-fold (0.23 log units) between middle value and limit.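

In this assay, among the compounds shown here, hydroxy in place of hydrogen on this saturated ring carbon gives an at least 1.7-fold higher number from compound 2 to compound 3 (0.23 log units; that floor lies within the scatter), the first measured change at this position. For compound 3 the reading is a limit, not a number: the limit of > 25 ug/mL in this assay, at which 1 of the 3 values shown sits. On these data alone, the change gave no lower number here, but the floor of the step does not clearly separate compound 3 from compound 2, and the true size of the step remains unknown.

As far as these compounds go, how an amine, a methoxy group or a fluorine atom would read on this ring carbon remains open. So does the result of adding hydroxy here to compound 1.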